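From Furanyl Ketone to a Hydroxy Lactol Side Chain

The source may hold more compounds than are shown below. What is called first, only, known or untested is meant among the compounds shown, and "the series" means these compounds.

Compound 1 `C=C(C)CCC[C@]1(C)C2=CCC[C@](C)(CC(=O)c3ccoc3)[C@H]2CC[C@H]1C` gives in a functional assay on HL-60 cells (Homo sapiens) for antiproliferative activity, read by XTT assay, with a stated time of 72 h (a lower number here means a stronger inhibitor, a higher number a weaker inhibitor), only a limit, > 100000 nM (the limit of > 100000 nM in this assay, at which 1 of the 3 values shown sits). Compound 3 `CC(C)=CCC[C@]1(C)C2=CCC[C@](C)(CC(=O)c3ccoc3)[C@H]2CC[C@H]1C` gives 57800 nM, and an at least 1.7-fold lower number from compound 1 to compound 3 (0.23 log units; that floor lies within the scatter). Within the data shown here, compound 2 `C=C(C)CC[C@]1(C)C2=CCC[C@](C)(C[C@@H](O)c3ccoc3)[C@H]2CC[C@H]1C` gives 28700 nM; no single step joins it to compound 1, so the two numbers are simply set side by side. Compound 4 `C=C(C)CCC[C@]1(C)C2=CCC[C@](C)(C[C@@H](O)C3=CC(=O)OC3O)[C@H]2CC[C@H]1C` differs from compound 1 by a group of 9 heavy atoms (5 carbon, 4 oxygen; one five-membered non-aromatic ring with 1 hetero atom) in place of a group of 7 heavy atoms (5 carbon, 2 oxygen; one five-membered aromatic ring with 1 hetero atom), on a saturated chain carbon bound to a saturated ring carbon. Among the measured compounds shown here, none of the measured steps alters this part of the side chain, so the measured step touches only the alkene and offers no direct guide. Because compound 1 sits at the limit (the limit of > 100000 nM in this assay, at which 1 of the 3 values shown sits), the estimate for compound 4 is 40000 nM, between 8000 nM and 200000 nM. The expected step is an at least 2.5-fold lower number from compound 1 to compound 4 (0.39 log units; beyond the scatter).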

Compound 4, half-maximal inhibitory concentration: 3200 nM
Estimate against measurement, compound 4: 13-fold (1.10 log units) above; the measured number lies below the stated range.
By their numbers in this assay, from the lowest: compound 4; then compounds 2 and 3 (each within the scatter of the next). At a limit, above all of these: compound 1.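

In this assay, setting the new lactol group in place of the (furan-3-yl)carbonyl, on a saturated chain carbon bound to a saturated ring carbon, gives an at least 31-fold lower number from compound 1 to compound 4 (1.49 log units; beyond the scatter) and this is the only step shown at this place. Unlike the alkene step, whose floor stayed within the scatter, it lies beyond the scatter. Its size is a floor, since compound 1 stands at a limit: the limit of > 100000 nM in this assay, at which 1 of the 4 values shown sits.

The ring and the chain hydroxyl change together in this step, and the compounds shown do not tell their shares apart. From the compounds shown here alone, whether an amine or a carboxylic acid in place of the ring hydroxyl would keep the number this low stays open.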